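Phenyl for Amino on a Triazole Nitrogen

The source may report more compounds than this note shows. Statements on the series, on what has been measured and on what is new or still open speak of the compounds shown alone.

The study measured three chromone-bearing thioethers in a functional assay on MCF7 cells (Homo sapiens) for cytotoxicity, read by MTT assay, with a stated time of 72 h; a lower number here means a stronger inhibitor, a higher number a weaker inhibitor. Compound 1 `O=c1cc(CSc2nc3ccccc3s2)oc2ccccc12` reaches only the limit of the assay, reported as > 25000 nM rather than a number. Compound 3 `Cc1nnc(SCc2cc(=O)c3ccccc3o2)s1` is likewise reported only as a limit, > 25000 nM. Compound 2 `Cc1cc(C)n2nc(SCc3nnc(SCc4coc5ccccc5c4=O)n3N)nc2n1` also gives a limit, > 25000 nM, and no number. Compound 2 therefore stands exactly where every other measured value stands, at the limit of > 25000 nM in this assay, at which 3 of the 3 values shown sit, and none of the three compounds can be ordered against another on these numbers.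

Compound 4 `Cc1cc(C)n2nc(SCc3nnc(SCc4coc5ccccc5c4=O)n3-c3ccccc3)nc2n1` has not yet been measured in this assay. It differs from compound 2 in a single place: phenyl in place of amino on an aromatic nitrogen. The phenyl enters on an aromatic nitrogen of a five-membered aromatic ring with 3 nitrogen, two ring bonds from the ring nitrogen. Among the measured compounds shown here, no measured step in the set covers this change, so its size is unknown. Given that every measured value in this assay is a limit, the expected step is a step that the limit leaves unreadable from compound 2 to compound 4, which amounts to none beyond the scatter. Compound 4 is accordingly estimated at 30000 nM in this assay, with a range from 8000 nM to 100000 nM, and the result is expected most likely to be reported again only as a limit.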

Compound 4, half-maximal inhibitory concentration: > 25000 nM
Compound 4 ended at the assay's limit; the forecaster's own chance of this, stated with the estimate: 75%; the middle value lies beyond the limit too.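

Compound 4 gives > 25000 nM, which is a limit and not a number. With compound 2 also reported only as a limit, no step can be read between compound 2 and compound 4: the limit of > 25000 nM in this assay, at which 4 of the 4 values shown sit.

The compounds shown leave open whether phenyl and amino on that aromatic nitrogen differ at all in cytotoxicity, and how the four compounds rank.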